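The source may hold more compounds than are shown below. What is called first, only, known or untested is meant among the compounds shown, and "the series" means these compounds.

Compound 1 `CCC/C=C/C(=O)Nc1cccc(Oc2nc(Nc3ccn(C)n3)nc3c2CSCC3)c1` carries a pent-1-en-1-yl group on its carbonyl carbon. Within the data shown here, in a functional assay on MCF7 cells (Homo sapiens) for antiproliferative activity, read by MTT assay, with a stated time of 72 h (on this read-out higher numbers stand for weaker inhibition and lower numbers for stronger inhibition), compound 1 gives 22600 nM, the only actual number so far. Compound 2 `C=C(C)C(=O)Nc1cccc(Oc2nc(Nc3ccn(C)n3)nc3c2CSCC3)c1` has 1-methylethenyl in that place instead. Compound 2 reads > 50000 nM, which is a limit of the assay and not a number. The swap at the carbonyl carbon shows up as an at least 2.2-fold higher number from compound 1 to compound 2 (0.34 log units; beyond the scatter), a step beyond the scatter. Compound 3 `CCC/C=C/C(=O)Nc1cccc(Oc2nc(Nc3ccc(OC)cc3)nc3c2CSCC3)c1` keeps the pent-1-en-1-yl group and differs at the other end of the molecule: 4-methoxyphenyl in place of 1-methyl-1H-pyrazol-3-yl on a nitrogen on an aromatic ring. There, 4-methoxyphenyl stands in place of 1-methyl-1H-pyrazol-3-yl on a nitrogen on an aromatic ring. Among the measured compounds shown here, no measured step touches this place, so the one step available gives no guide to size or direction here. With nothing pointing either way, the expected move in this assay is none beyond the scatter, and the estimated step reads a 1.3-fold lower number from compound 1 to compound 3 (0.10 log units; within the scatter). For compound 3 the expected value is 18000 nM, with an estimated range from 5000 nM to 50000 nM.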

Compound 3, half-maximal inhibitory concentration: > 50000 nM
Compound 3: only a limit was reported; the forecaster's own chance of this, stated with the estimate: 20%; at least 2.7-fold (0.44 log units) between middle value and limit.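

Among these compounds, the place on the nitrogen, which no earlier step touched, turns out not to be neutral in this assay: 4-methoxyphenyl in place of 1-methyl-1H-pyrazol-3-yl gives an at least 2.2-fold higher number from compound 1 to compound 3 (0.34 log units; beyond the scatter). This step runs in the same direction as the earlier change at the carbonyl carbon, so among these three compounds, a change at either of the two places moves the number upward from compound 1, and neither change goes against that. How large either step really is stays unknown, because compound 3, like compound 2, sits at a limit of the assay and not at a number, so each step has a lower bound only: the limit of > 50000 nM in this assay, at which 2 of the 3 values shown sit.

The compounds shown leave open whether the loss at this nitrogen goes with the phenyl ring itself or with its methoxy group, which a plain phenyl or a 4-hydroxyphenyl on the same nitrogen would separate. They also leave open whether another heteroaromatic group there, such as a pyridinyl or a 1-ethyl-1H-pyrazol-3-yl, would give a lower number than compound 1 does.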